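From 4-fluorophenyl to 4-methoxyphenyl in a chloro-substituted series

A few compounds are considered here, and "the series" means these few. Any claim that something is new, unique, unknown or untested is made for them only; others in the source may bear on it.

Measured in a functional assay on A549 cells (Homo sapiens) for antiproliferative activity, read by MTT assay, with a stated time of 48 h; on this read-out lower numbers stand for stronger inhibition and higher numbers for weaker inhibition:
- compound 1 `Fc1ccc(-c2nn(-c3ccccc3)cc2-c2nc3ccccc3[nH]2)cc1`: 1510 nM
- compound 2 `Fc1ccc(-c2nn(-c3ccccc3)cc2-c2nc3cc(Cl)ccc3[nH]2)cc1`: 1320 nM

Compound 2, at 1320 nM, is level with compound 1, at 1510 nM, since the gap between them lies within the scatter. With only these two numbers, neither can be ranked above the other in this assay.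

The next compound, compound 3 `COc1ccc(-c2nn(-c3ccccc3)cc2-c2nc3cc(Cl)ccc3[nH]2)cc1`, keeps everything in compound 2 except one group, with methoxy in place of fluoro on an aromatic carbon.

For the measured compounds named here, only one measured step is available, a 1.1-fold lower number from compound 1 to compound 2 (0.06 log units; within the scatter). It is a different change, chloro in place of hydrogen, so it bears on the new change only indirectly, showing that this series did not move with that substitution. Going by the values given here, no measured compound shows what replacing fluoro does, so the data give no direction. The expectation therefore rests on compound 2 at 1320 nM, and no step beyond the scatter is anticipated. The expected step is a 1.1-fold higher number from compound 2 to compound 3 (0.03 log units; within the scatter). For compound 3 the estimated value is 1400 nM, with an expected range of 550 nM to 3500 nM.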

Compound 3, half-maximal inhibitory concentration: 3130 nM
The estimate for compound 3 lay 2.2-fold (0.35 log units) below the measured number, and the stated range covers the measured number.
By their numbers in this assay, from the lowest: compounds 2 and 1 (each within the scatter of the next); then compound 3.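

In this assay, the change from 4-fluorophenyl to 4-methoxyphenyl gives a 2.4-fold higher number from compound 2 to compound 3 (0.37 log units; beyond the scatter), and so moves the number beyond the scatter, which the earlier chloro in place of hydrogen did not do (a 1.1-fold lower number from compound 1 to compound 2 (0.06 log units; within the scatter)). The aromatic carbon para to a large group is therefore a place where the series responds to a change, and in this single case the direction is towards weaker inhibition when methoxy, with 2 heavy atoms and 1 hydrogen-bond acceptor, takes the place of fluoro, with 1 heavy atom and no hydrogen-bond acceptor. No measurement at hand speaks to what lies behind this step.

On these data alone, it remains open whether this direction belongs to methoxy alone or would also hold at the same carbon for a hydroxy group, an amine or a longer ether chain such as ethoxy. It is also open whether the step would be the same size on the core of compound 1, which lacks the chloro group, as it is in the chloro-substituted pair shown here.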